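A few compounds are considered here, and "the series" means these few. Any claim that something is new, unique, unknown or untested is made for them only; others in the source may bear on it.

Working notes on the series. The shared core of compound 1 `O=S(=O)(Nc1ccc(-c2nc3ccccc3o2)cc1)c1ccc(Cl)s1` is kept throughout; the variable part is the group on the sulfonyl sulfur. In an assay on cells for inhibition of HSP60/HSP10 (Homo sapiens), with a stated time of 60 min (a higher number here means a weaker inhibitor, a lower number a stronger inhibitor), compound 1 gives 31000 nM. Compound 2 `O=S(=O)(Nc1ccc(-c2nc3ccccc3o2)cc1)c1ccccc1O` in this assay gives only > 100000 nM. That value is a limit of the assay and not a number (the limit of > 100000 nM in this assay, at which 1 of the 2 values shown sits). The step of an at least 3.2-fold higher number from compound 1 to compound 2 (0.50 log units; beyond the scatter) therefore places compound 2 at the weak end of what has been measured, with only a range known for it. Compound 3 `COc1cccc(S(=O)(=O)Nc2ccc(-c3nc4ccccc4o3)cc2)c1` differs from compound 2 by 3-methoxyphenyl in place of 2-hydroxyphenyl on a sulfonyl sulfur. For the measured compounds named here, the sole measured step at this position is an at least 3.2-fold higher number from compound 1 to compound 2 (0.50 log units; beyond the scatter), an at least modest loss; no measured pair fixes the size of a change from a 2-hydroxyphenyl to a 3-methoxyphenyl there, so the expected step is uncertain in direction and size, an at least 1.6-fold lower number from compound 2 to compound 3 (0.22 log units; that floor lies within the scatter). Compound 3 is expected to give 60000 nM in this assay, with a range of 20000 nM to 200000 nM, and a limit is a real possibility.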

Compound 3, half-maximal inhibitory concentration: 80000 nM
Beside the measured number, compound 3's estimate is 1.3-fold (0.12 log units) below it; the measured number falls inside the stated range.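

The loss on leaving 5-chlorothiophen-2-yl now has a size and not only a floor: in this assay there is a 2.6-fold higher number from compound 1 to compound 3 (0.41 log units; beyond the scatter), with 3-methoxyphenyl on the sulfonyl sulfur. The change from 2-hydroxyphenyl to 3-methoxyphenyl shows an at least 1.2-fold lower number from compound 2 to compound 3 (0.09 log units; that floor lies within the scatter), so it remains unsettled whether these two groups differ at all in this assay. The value of compound 2 is a limit and not a number, so this step has only a floor: the limit of > 100000 nM in this assay, at which 1 of the 3 values shown sits.

The compounds shown leave open whether the result for compound 1 rests on the chlorine or on the sulfur-containing ring, which a plain thiophen-2-yl group would separate. Also open, from the compounds shown here alone, is how a 3-hydroxyphenyl, a 2-methoxyphenyl or a phenyl carrying an amine or a carboxylic acid would behave on the sulfonyl sulfur.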